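The compounds below may be only part of what the source reports. "The series", "measured", "known", "first", "only" and "open" are said of these compounds alone.

Compound 1, `N#Cc1ccc(N2CCN(C(=S)SCc3ccc(C(=O)Nc4ccccc4N)cc3)CC2)cc1`: 37.6%
Compound 2, `CCN(Cc1ccncc1)C(=S)SCc1ccc(C(=O)Nc2ccccc2N)cc1`: 85.2%

In a functional assay on MGC-803 cells (Homo sapiens) for antiproliferative activity, read by CCK-8 assay, with a stated time of 72 h, tested at 8 uM (on this read-out lower numbers stand for a weaker effect and higher numbers for a stronger effect at the one concentration tested), compound 1 gives 37.6%, the lowest of the two numbers shown. Compound 2 gives 85.2% in this assay, a number that stands beyond the scatter above compound 1. Compound 3, `Nc1ccccc1NC(=O)c1ccc(CSC(=S)N2CCN(C3CCCCC3)CC2)cc1`, has not yet been measured. It differs from compound 1 in one place: cyclohexyl in place of 4-cyanophenyl on an amine nitrogen in a ring. The rest of the shared core is unchanged. Among the measured compounds shown here, no measured pair shows the effect of this exact change, so the direction of the step is uncertain. For the measured compounds named here, the one other measured compound, compound 2, reaches a much higher number, but its structure differs from compound 1 in more than this one place. Compound 3 is expected to come in somewhat higher than compound 1, with an expected step of a number 17.4 percentage points higher from compound 1 to compound 3 (beyond the scatter) that is modest and not surely beyond the scatter. The estimate for compound 3 is 55%, with a range from 25% to 85%.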

Compound 3, a percentage reported as inhibition, at one concentration (the size of the read-out at that concentration, not a potency): 75.3%
Estimate against measurement, compound 3: 20.3 percentage points below; measured number inside the range.
By their numbers in this assay, from the lowest: compound 1; then compounds 3 and 2 (each within the scatter of the next).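

In this assay, among the compounds shown here, cyclohexyl in place of 4-cyanophenyl on the amine nitrogen in the ring gives a number 37.7 percentage points higher from compound 1 to compound 3 (beyond the scatter) with the rest of the shared core unchanged, the first single-place change that can be read here. This shows that the number depends strongly on the group at this position. It also shows that neither an aromatic ring nor a nitrile is required there for a high number at the one concentration tested, although no measured finding explains the step.

This single change alters the ring and removes the nitrile together, so the contribution of each remains unresolved. A plain phenyl group on the same nitrogen would separate the two, while a methyl group would test whether a six-membered carbon ring is needed at all.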